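The source may hold more compounds than are shown below. What is called first, only, known or untested is meant among the compounds shown, and "the series" means these compounds.

Compound 1 `COc1cc(-c2cc(/C=C/C(=O)c3ccc(N)cc3)[nH]n2)cc(OC)c1OC`: 2850 nM
Compound 2 `COc1cc(-c2cc(/C=C/C(=O)c3ccc(Cl)c(Cl)c3)[nH]n2)cc(OC)c1OC`: 13900 nM
Compound 3 `COc1ccc(C(=O)/C=C/c2cc(-c3cc(OC)c(OC)c(OC)c3)n[nH]2)cc1`: 4140 nM

In a functional assay on SK-MEL-2 cells (Homo sapiens) for inhibition, read by sulforhodamine B assay, with a stated time of 48 h (on this read-out lower numbers stand for stronger inhibition of growth and higher numbers for weaker inhibition of growth), compound 3 stands second highest of the three numbers; compound 1 lies nearest, with a 1.5-fold higher number from compound 1 to compound 3 (0.16 log units; within the scatter), and compound 2 lies furthest, with a 3.4-fold lower number from compound 2 to compound 3 (0.53 log units; beyond the scatter). Compound 4 `COc1cc(-c2cc(/C=C/C(=O)c3ccc(F)c(F)c3)[nH]n2)cc(OC)c1OC` differs from compound 3 by 3,4-difluorophenyl in place of 4-methoxyphenyl on a carbonyl carbon. For the measured compounds named here, the step that bears most directly on this change is the one from compound 2 to compound 3, a 3.4-fold lower number from compound 2 to compound 3 (0.53 log units; beyond the scatter), which is the same kind of exchange run the other way with chlorine instead of fluorine. The step from compound 1 to compound 2, a 4.9-fold higher number from compound 1 to compound 2 (0.69 log units; beyond the scatter), points the same way: the dihalogenated aryl on the carbonyl gave the higher number in both comparisons. Compound 4 is therefore expected to show a modest rise in this assay, a 2.2-fold higher number from compound 3 to compound 4 (0.34 log units; beyond the scatter), though how closely the difluoro compound tracks the dichloro compound is not known from these three measurements. Compound 4 is estimated at 9000 nM, with a range of 3500 nM to 25000 nM.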

Compound 4, concentration for 50% growth inhibition: 2300 nM
Compound 4: the middle estimate sits 3.9-fold (0.59 log units) above what was measured; the whole stated range lies above it.
By their numbers in this assay, from the lowest: compounds 4, 1 and 3 (each within the scatter of the next); then compound 2.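

In this assay the two dihalogenated aryl groups on the carbonyl carbon do not behave alike: the exchange of 3,4-dichlorophenyl for 3,4-difluorophenyl gives a clear step (a 6.0-fold lower number from compound 2 to compound 4 (0.78 log units; beyond the scatter)), so the earlier dichloro result does not carry over to the difluoro compound. The 3,4-difluorophenyl group cannot be told apart from 4-methoxyphenyl (a 1.8-fold lower number from compound 3 to compound 4 (0.26 log units; within the scatter)) or from 4-aminophenyl (a 1.2-fold lower number from compound 1 to compound 4 (0.09 log units; within the scatter)), which leaves compound 2 alone in standing apart among these four compounds. Nothing available here accounts for the gap between the two halogenated compounds.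

The compounds shown leave open whether a single halogen, as in 4-fluorophenyl or 4-chlorophenyl, would sit with compound 4 or with compound 2. They also leave open how an unsubstituted phenyl or a carboxylic acid on the aryl ring would read at this place.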